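Removing the nitro group from a sulfonamide series

The compounds below may be only part of what the source reports. "The series", "measured", "known", "first", "only" and "open" are said of these compounds alone.

Compound 1 `CC(=O)c1ccc(NC(=O)CN(C(=O)c2ccccc2)S(=O)(=O)c2ccc(C)cc2)cc1` gives 17.9% in a functional assay for inhibition, read by spectrophotometry, with a stated time of 20 min, tested at 1 mg/mL; on this read-out higher numbers stand for a stronger effect at the one concentration tested and lower numbers for a weaker effect.
Compound 2 `CC(=O)c1ccc(NC(=O)CN(C(=O)c2ccccc2)S(=O)(=O)c2ccc([N+](=O)[O-])cc2)cc1` gives 20.6% in this assay.

Compound 2 stands highest of the two numbers in this assay, but its nearest neighbour, compound 1, lies within the scatter of it. Compound 3 `CC(=O)c1ccc(NC(=O)CN(C(=O)c2ccccc2)S(=O)(=O)c2ccccc2)cc1` differs from compound 2 by hydrogen in place of nitro on an aromatic carbon. Among the measured compounds shown here, the only step that bears on this change is a number 2.7 percentage points higher from compound 1 to compound 2 (within the scatter), which swapped a nitro for a methyl at the same position and moved the read-out within the scatter. No step beyond the scatter is therefore expected for compound 3; its estimated value is 19% with a range of 9% to 30%, a step of a number 1.6 percentage points lower from compound 2 to compound 3 (within the scatter).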

Compound 3, a percentage reported as inhibition, at one concentration (the size of the read-out at that concentration, not a potency): 40.5%
Compound 3: the middle estimate sits 21.5 percentage points below what was measured; measured number above the stated range.
By their numbers in this assay, from the lowest: compounds 1 and 2 (each within the scatter of the next); then compound 3.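

At this position, on an aromatic carbon para to a large group, hydrogen stands apart in this assay: the change from 4-nitrophenyl to phenyl gives a number 19.9 percentage points higher from compound 2 to compound 3 (beyond the scatter), and hydrogen in place of methyl gives a number 22.6 percentage points higher from compound 1 to compound 3 (beyond the scatter). The earlier swap between nitro and methyl could not show that both substituents sit well under hydrogen here. Nothing available explains this difference. The compounds shown leave open whether any group at this position keeps the read-out of compound 3. Fluorine, an amine or a carboxylic acid there might fall with compound 3 or with compound 1 and compound 2.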